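Cytotoxicity series: distal aryl changes, compound 3 next

This account rests on a few compounds, and the source may have more. Where it says the series, first, only, none or still open, it means among the compounds named here.

The series shares one core carrying an ethyl ester chain and an isopropyl amide, varied only at the distal aryl ring. Compound 1 is `CCOC(=O)CCCCCOc1cccc(CN(C(=O)c2ccc(-c3ccc4ccccc4c3)cc2)C(C)C)c1`. In an ADME assay on BJ cells (Homo sapiens) for cytotoxicity, read by CellTiter-Glo and resazurin assay, with a stated time of 72 h (on this read-out lower numbers stand for an effect already at smaller amounts and higher numbers for an effect only at larger amounts of compound), compound 1 reports a limit, > 26000 nM. Compound 2 is `CCOC(=O)CCCCCOc1cccc(CN(C(=O)c2ccc(-c3cccc(OC(C)C)c3)cc2)C(C)C)c1`. In this assay compound 2 likewise reports a limit, > 26000 nM. The step that the two limits leave unreadable from compound 1 to compound 2 therefore has no readable size, since both values sit at the limit of > 26000 nM in this assay, at which 2 of the 2 values shown sit. Within the data shown here, compound 2 thus stands at the limit of this assay, alongside the one other value shown, with no number to rank it.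

Compound 3 is `CCOC(=O)CCCCCOc1cccc(CN(C(=O)c2ccc(-c3cc(OC)ccc3F)cc2)C(C)C)c1`. It differs from compound 2 by 2-fluoro-5-methoxyphenyl in place of 3-isopropoxyphenyl on an aromatic carbon. Among the measured compounds shown here, no measured step bears readably on this change: the single measured step is hidden by the two limits. With both values shown at the limit of > 26000 nM in this assay, at which 2 of the 2 values shown sit, the expectation for compound 3 is that this assay again returns a limit rather than a number, and the step that the limit leaves unreadable from compound 2 to compound 3 is estimated as none beyond the scatter. Compound 3 is expected at 30000 nM, within 15000 nM to 80000 nM, most probably reported as a limit.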

Compound 3, half-maximal effective concentration: > 26000 nM
Compound 3 ended at the assay's limit (the forecaster's own chance of this, stated with the estimate: 85%); the middle value lies beyond the limit too.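

Among these compounds, compound 1, compound 2 and compound 3 all sit at a limit of the assay, so no step among them can be read in this assay: the limit of > 26000 nM in this assay, at which 3 of the 3 values shown sit.

The compounds shown leave open whether any distal aryl group on the shared core gives a numerical half-maximal effective concentration in this assay.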